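This account rests on a few compounds, and the source may have more. Where it says the series, first, only, none or still open, it means among the compounds named here.

Compound 2, `COc1nc2ccc(Br)cc2cc1C(c1ccccc1)n1cc(CCO)nn1`, and compound 1, `CCCCc1cn(C(c2ccccc2)c2cc3cc(Br)ccc3nc2OC)nn1`, share one core and differ only in the group carried on the five-membered ring. In an ADME assay on PC-3 cells (Homo sapiens) for cytotoxicity, read by sulforhodamine B assay, with a stated time of 48 h, tested at 10 uM (a higher number here means more inhibition at the concentration tested (going by the name of the read-out), a lower number less inhibition), compound 2 gives 15.5%, the higher of the two numbers measured, while compound 1 gives 5.54%; the step of a number 10 percentage points higher from compound 1 to compound 2 (within the scatter) lies within the scatter, so the two compounds cannot be ordered on it. Compound 3, `COc1nc2ccc(Br)cc2cc1C(c1ccccc1)n1cc(-c2ccccc2C(F)(F)F)nn1`, has not yet been measured in this assay. It differs from compound 2 by 2-(trifluoromethyl)phenyl in place of 2-hydroxyethyl on an aromatic carbon. Among the compounds with values here, the only measured step, from compound 1 to compound 2, exchanges one small chain for another at the same place; it was within the scatter and says little about bringing a ring onto that carbon, so no measured step bears closely on the change to compound 3. Without a comparable step, the expectation for compound 3 rests on the shared core alone and is wide: compound 3 is estimated to give 22%, between 2% and 55%, which would mean an expected step of a number 6.5 percentage points higher from compound 2 to compound 3 (within the scatter) that may not exceed the scatter.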

Compound 3, a percentage reported as inhibition, at one concentration (the size of the read-out at that concentration, not a potency): 17.4%
For compound 3 the middle estimate is 4.6 percentage points above the measured one, within the range that was stated.
By their numbers in this assay, from the lowest: compounds 1, 2 and 3 (each within the scatter of the next, the first and the last beyond it).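

In this assay, the 10-heavy-atom 2-(trifluoromethyl)phenyl, with its six-membered aromatic ring, can stand on this aromatic carbon of the five-membered ring in place of the 3-heavy-atom 2-hydroxyethyl, with a number 1.9 percentage points higher from compound 2 to compound 3 (within the scatter). Within the data shown here, replacing butyl with the same group gives a number 11.9 percentage points higher from compound 1 to compound 3 (beyond the scatter), the first step in this small set to exceed the scatter, though only modestly, so a ring-bearing group at this carbon can be separated from butyl but not from 2-hydroxyethyl. The information supplied offers no measured explanation for either step.

The compounds shown leave open whether the aromatic ring or its trifluoromethyl group matters more to the step from butyl, a question that an unsubstituted phenyl at this carbon would address directly. They also leave open whether a basic amine or a carboxylic acid at the end of a short chain on this carbon would give a number distinct from those of compound 2 and compound 3 in this assay.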